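A few compounds are considered here, and "the series" means these few. Any claim that something is new, unique, unknown or untested is made for them only; others in the source may bear on it.

In a functional assay on HEK293 cells for antagonist activity at Voltage-dependent L-type calcium channel subunit alpha-1C (Oryctolagus cuniculus), read by FLIPR (a lower number here means a stronger inhibitor, a higher number a weaker inhibitor), compound 1 `COC(=O)C1=C(C)NC(C)=C(C(=O)OC2C=CCCC2)C1c1cccc([N+](=O)[O-])c1` gives 10 nM, and compound 2 `COC(=O)C1=C(C)NC(C)=C(C(=O)OCCCCc2ccccc2)C1c1cccc([N+](=O)[O-])c1` gives 10 nM. Going by the values given here, the only step measured so far, no change at the digits printed from compound 1 to compound 2 (within the scatter), swapped the whole ester side chain without moving the number, so compound 2 stands level with compound 1. Compound 3 `COC(=O)C1=C(C)NC(C)=C(C(=O)OCCCCc2ccc(OC)cc2)C1c1cccc([N+](=O)[O-])c1` changes that same side chain again, this time by methoxy in place of hydrogen on an aromatic carbon. Given that the larger exchange left the read-out unmoved, this smaller addition is expected to do the same, with no change at the digits printed from compound 2 to compound 3 (within the scatter) staying inside the scatter. Compound 3 is therefore estimated at 10 nM, within 4 nM to 30 nM.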

Compound 3, half-maximal inhibitory concentration: 17 nM
The estimate for compound 3 lay 1.7-fold (0.23 log units) below the measured number; measured number inside the range.
By their numbers in this assay, from the lowest: compounds 1, 2 and 3 (each within the scatter of the next).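

In this assay adding methoxy to the aromatic ring, para to a large group, gives a 1.7-fold higher number from compound 2 to compound 3 (0.23 log units; within the scatter) and so shows that this ring of the side chain carries the new group with no readable change. The full side-chain exchange gives a 1.7-fold higher number from compound 1 to compound 3 (0.23 log units; within the scatter) and leaves the 4-(4-methoxyphenyl)butyl ester indistinguishable from the cyclohex-2-en-1-yl ester. No available evidence bears on this result.

Still open, from the compounds shown here alone, is whether an amine or a carboxylic acid in place of methoxy would leave the read-out unchanged. Whether a longer chain than butyl would do the same also remains unanswered.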